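The compounds below may be only part of what the source reports. "The series", "measured", "known", "first", "only" and "open" are said of these compounds alone.

Of the compounds shown here, three have so far been tested in a functional assay on OVCAR-8 cells (Homo sapiens) for cytotoxicity, read by sulforhodamine B assay, with a stated time of 48 h; a higher number here means a weaker inhibitor of growth, a lower number a stronger inhibitor of growth. Compound 1 `ClCc1ccc(Cn2cnc3c(Cl)ncnc32)cc1` gives 3020 nM in this assay. Compound 2 `Nc1nc(Cl)c2ncn(Cc3ccc(CCl)cc3)c2n1` carries the same core with a single alteration, (amino in place of hydrogen on an aromatic carbon). In this assay compound 2 gives 5130 nM. The step of a 1.7-fold higher number from compound 1 to compound 2 (0.23 log units; within the scatter) shows that adding the amino group left the growth inhibition essentially where it was.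

Compound 3 `ClCc1ccccc1Cn1cnc2c(Cl)ncnc21` is built from the same atoms as compound 1, joined differently; the difference between the two cores is not broken down here. In this assay compound 3 gives 2240 nM. Its number and that of compound 1 lie within the usual scatter of each other, so the two cannot be ranked; the gap to compound 2 lies beyond the scatter.

Compound 4 `Nc1nc(Cl)c2ncn(Cc3ccccc3CCl)c2n1` has not yet been measured. It differs from compound 3 by amino in place of hydrogen on an aromatic carbon. Going by the values given here, the description of the place where the amino group enters matches word for word the one for the change from compound 1 to compound 2, so this is the same change made on the core of compound 3. Because a 1.7-fold higher number from compound 1 to compound 2 (0.23 log units; within the scatter) stayed within the scatter, the same change on compound 3 is expected to do little. The expected step of a 1.7-fold higher number from compound 3 to compound 4 (0.23 log units; within the scatter) is estimated to mirror the earlier one. Compound 4 is therefore expected to give about 3800 nM in this assay. For compound 4 the estimate is expected to run from 1800 nM to 8000 nM.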

Compound 4, concentration for 50% growth inhibition: 3890 nM
Compound 4: middle estimate off by 1.0-fold (0.01 log units), on the low side; low and high end bracket the measured number.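

In this assay adding the amino group gives a 1.7-fold higher number from compound 3 to compound 4 (0.24 log units; within the scatter) and so, on the core of compound 3 as well, leaves growth inhibition essentially where it was. Set beside the earlier step, the change behaves alike on the two cores: the same change on two cores in this assay, a 1.7-fold higher number (0.23 log units; within the scatter) from compound 1 to compound 2 and a 1.7-fold higher number (0.24 log units; within the scatter) from compound 3 to compound 4, 1.0-fold (0.01 log units) apart, within the scatter of two such steps. This shows that, on these two cores, the amino group can be added with no measurable change in this cell assay, but it does not show that the same would hold on any other core in the series, and two steps that each lie within the scatter cannot separate a small real effect from no effect at all.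

The compounds shown leave open what other groups would do at this same aromatic carbon, between the two ring nitrogen atoms, such as a methyl group or a hydroxyl group in place of the amino group. On these data alone, all four compounds also keep the chloro group and the chloromethyl group, so it remains open how the numbers would move if a methoxy group replaced the chloro group or a hydroxymethyl group replaced the chloromethyl group.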